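Methoxy for hydrogen in the series of compound 3

This account rests on a few compounds, and the source may have more. Where it says the series, first, only, none or still open, it means among the compounds named here.

Compound 1 `O=C(/C(=C/C1CCCCC1)CCl)c1ccccc1` gives 22000 nM in a functional assay on WiDr cells (Homo sapiens) for inhibition, read by sulforhodamine B assay, with a stated time of 48 h; a lower number here means a stronger inhibitor of growth, a higher number a weaker inhibitor of growth. Compound 2 `CC(=O)OC/C(=C/c1ccc(Cl)cc1)C(=O)c1ccc(Cl)cc1` gives 17000 nM in this assay, and compound 3 `C=C(C/C(=C\c1ccccc1)C(=O)c1ccccc1)C(=O)c1ccccc1` gives 18000 nM. The three numbers lie within the usual scatter of one another, so compound 3 cannot be set apart from compound 1 or compound 2 on these figures. Compound 4 `C=C(C/C(=C\c1ccc(OC)cc1)C(=O)c1ccccc1)C(=O)c1ccccc1` differs from compound 3 by methoxy in place of hydrogen on an aromatic carbon. Among the measured compounds shown here, no pair of measured compounds shows this difference, and no measured compound carries a methoxy group at all. Compound 3 at 18000 nM is the only anchor. The step is expected to stay within the scatter, a 1.1-fold lower number from compound 3 to compound 4 (0.05 log units; within the scatter), in no set direction. Compound 4 is therefore estimated at 16000 nM, between 6000 nM and 45000 nM.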

Compound 4, concentration for 50% growth inhibition: 470 nM
The estimate for compound 4 lay 34-fold (1.53 log units) above the measured number, outside the stated range (below it).
By their numbers in this assay, from the lowest: compound 4; then compounds 2, 3 and 1 (each within the scatter of the next).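

In this assay, methoxy in place of hydrogen on this aromatic carbon, para to a large group, gives a 38-fold lower number from compound 3 to compound 4 (1.58 log units; beyond the scatter), a large step beyond the scatter. The earlier compounds shown here gave no sign of this: the position responds strongly to this change, and phenyl to 4-methoxyphenyl brings a much stronger inhibitor of growth. Nothing available bears on the reason for the step.

From the compounds shown here alone, whether the gain is specific to methoxy stays open. A hydroxyl, an amine or a longer alkoxy chain on this carbon could give a different number.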